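Permeability Step From Fluorophenyl to Pyridinyl Sulfone

The compounds below may be only part of what the source reports. "The series", "measured", "known", "first", "only" and "open" are said of these compounds alone.

Compound 1, `CCCCc1nc(=O)c(S(=O)(=O)c2ccc(-c3ccnc(NC(=O)C4CC4)c3)cc2)c(O)n1-c1c(OC)cccc1OC`: 183 nm/s
Compound 2, `CCCCc1nc(=O)c(S(=O)(=O)c2ccc(-c3ccc(F)cc3)cc2)c(O)n1-c1c(OC)cccc1OC`: 418 nm/s

Going by the values given here, in an ADME assay for permeability, using PAMPA, at pH 5.5 (on this read-out higher numbers stand for higher permeability and lower numbers for lower permeability), compound 2 gives the higher of the two numbers measured so far, and compound 1 is its nearest neighbour; the only measured step, a 2.3-fold higher number from compound 1 to compound 2 (0.36 log units; beyond the scatter), separates them.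

Compound 3, `CCCCc1nc(=O)c(S(=O)(=O)c2ccc(-c3cccnc3)cc2)c(O)n1-c1c(OC)cccc1OC`, is not yet measured in this assay. It differs from compound 2 in one place: pyridin-3-yl in place of 4-fluorophenyl on an aromatic carbon. The measured step bears on this change only loosely, since it exchanged a pyridinyl carrying a cyclopropylcarbonyl amino part for the fluorophenyl and gave a 2.3-fold higher number from compound 1 to compound 2 (0.36 log units; beyond the scatter), whereas the group entering here is a bare pyridin-3-yl with one hydrogen-bond acceptor. A modest decrease is expected, a 1.7-fold lower number from compound 2 to compound 3 (0.22 log units; within the scatter), smaller than that measured step. Compound 3 is therefore estimated at 250 nm/s, within a range from 120 nm/s to 500 nm/s.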

Compound 3, apparent permeability: 202 nm/s
Estimate against measurement, compound 3: 1.2-fold (0.09 log units) above; measured number inside the range.
By their numbers in this assay, from the lowest: compounds 1 and 3 (each within the scatter of the next); then compound 2.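

In this assay, a change as small as pyridin-3-yl in place of 4-fluorophenyl, on an aromatic carbon para to a large group, gives a 2.1-fold lower number from compound 2 to compound 3 (0.32 log units; beyond the scatter), so the step seen earlier does not need the larger group. Pyridin-3-yl and 2-((cyclopropylcarbonyl)amino)pyridin-4-yl, by contrast, give a 1.1-fold higher number from compound 1 to compound 3 (0.04 log units; within the scatter), so among these three compounds the cyclopropylcarbonyl amino part brings no difference that can be told from the scatter, and only the compound with 4-fluorophenyl stands apart. Nothing measured here explains why the numbers fall this way.

The compounds shown leave open whether the ring nitrogen or the loss of the fluorine accounts for the step, and a plain phenyl at this position would help separate the two. From the compounds shown here alone, how a pyridin-4-yl without the amide would compare also remains open.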